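Dimethylamino to Pyrrolidin-1-yl on the Carbonyl Carbon

This account rests on a few compounds, and the source may have more. Where it says the series, first, only, none or still open, it means among the compounds named here.

Compound 2 `COc1cc2c(cc1OC)C(CC(=O)N(C)C)CC2` gives the highest of the three numbers in a functional assay on the whole organism (strain Wistar) for inhibition, with Rattus norvegicus as the target, read by paw edema, with stated times of 60 min and 4 h, at a dose of 100 mg/kg by the oral route (a higher number here means more inhibition at the dose given (going by the name of the read-out), a lower number less inhibition), with 35.9%. Compound 1 `COc1cc2c(cc1OC)C(CC(=O)O)CC2` gives 23.9%, and compound 3 `COc1cc2c(cc1OC)C(CC(=O)NCc1ccccc1)CC2` gives 18.8%. Dimethylamino in place of hydroxy on the carbonyl carbon brought a number 12 percentage points higher from compound 1 to compound 2 (beyond the scatter), while benzylamino in place of dimethylamino brought a number 17.1 percentage points lower from compound 2 to compound 3 (beyond the scatter). Compound 4 `COc1cc2c(cc1OC)C(CC(=O)N1CCCC1)CC2` differs from compound 2 by pyrrolidin-1-yl in place of dimethylamino on a carbonyl carbon. Going by the values given here, no measured step exchanges dimethylamino for a related ring-bearing group on this carbonyl carbon; the steps into and out of compound 2 bracket it rather than set a direction. The expected step is therefore a number 2.9 percentage points lower from compound 2 to compound 4 (within the scatter), nothing beyond the scatter. Compound 4 is estimated at 33%, between 20% and 46%.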

Compound 4, a percentage reported as inhibition, in the whole organism at one dose (the size of the read-out at that dose, not a potency): 24.2%
Compound 4: middle estimate off by 8.8 percentage points, on the high side, within the range that was stated.
By their numbers in this assay, from the lowest: compounds 3, 1 and 4 (each within the scatter of the next); then compound 2.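

In this assay the ring of pyrrolidin-1-yl did not keep what dimethylamino gave on this carbonyl carbon, with a number 11.7 percentage points lower from compound 2 to compound 4 (beyond the scatter) for this change. With a number 0.3 percentage points higher from compound 1 to compound 4 (within the scatter) and a number 5.4 percentage points higher from compound 3 to compound 4 (within the scatter) as well, compound 4 cannot be told apart from compound 1 or compound 3, so among these four groups only dimethylamino stands apart. Nothing measured here bears on the reason for this drop. Going by these compounds, whether diethylamino, piperidin-1-yl or morpholin-4-yl on this carbonyl carbon would stand with compound 2 or with compound 4 remains open.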